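This account rests on a few compounds, and the source may have more. Where it says the series, first, only, none or still open, it means among the compounds named here.

Measured so far in a functional assay on A549 cells (Homo sapiens) for inhibition, read by CCK-8 assay, with a stated time of 72 h, tested at 10 uM; a higher number here means more inhibition of growth at the concentration tested, a lower number less inhibition of growth:
- compound 1 `COC(=O)c1ccc(NC(=O)C2(C(=O)Nc3ccc(Nc4ncc5cc(C(=O)N(C)C)n(C6CCCC6)c5n4)cc3)CC2)cc1`: 92%
- compound 2 `CN(C)C(=O)c1cc2cnc(Nc3ccc(NC(=O)C4(C(=O)Nc5ccc(C(F)(F)F)cc5)CC4)cc3)nc2n1C1CCCC1`: 87.9%

For the measured compounds named here, compound 2, at 87.9%, lies within the scatter of compound 1, the only other measured compound. Compound 3 `CN(C)C(=O)c1cc2cnc(Nc3ccc(NC(=O)C4(C(=O)Nc5ccc(C#N)cc5)CC4)cc3)nc2n1C1CCCC1` carries cyano in place of trifluoromethyl on an aromatic carbon, that is, cyano in place of trifluoromethyl on an aromatic carbon. Going by the values given here, the one measured step at this place is a number 4.1 percentage points lower from compound 1 to compound 2 (within the scatter), with trifluoromethyl in place of methoxycarbonyl. On that evidence, no step beyond the scatter is expected in this assay. The expected step is a number 0.1 percentage points higher from compound 2 to compound 3 (within the scatter). For compound 3 the estimated value is 88%, with an expected range of 78% to 95%.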

Compound 3, percent growth inhibition at one concentration: 95%
Compound 3: the middle estimate sits 7 percentage points below what was measured; the measured number falls inside the stated range.
By their numbers in this assay, from the lowest: compounds 2, 1 and 3 (each within the scatter of the next).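

In this assay, a third group on this aromatic carbon, para to a large group, still gives no step beyond the scatter: cyano in place of trifluoromethyl gives a number 7.1 percentage points higher from compound 2 to compound 3 (within the scatter), and cyano in place of methoxycarbonyl gives a number 3 percentage points higher from compound 1 to compound 3 (within the scatter). Going from the 4 heavy atoms of trifluoromethyl to the 2 of cyano therefore does not separate the compounds in this read-out. No further measurement bears on this result.

Open, as far as these compounds go, is whether an amine or a carboxylic acid at this place would hold the number. Also open is whether readings at a single concentration conceal differences among these three compounds.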